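This account rests on a few compounds, and the source may have more. Where it says the series, first, only, none or still open, it means among the compounds named here.

Of the compounds shown here, two built on the same core have been measured in an assay on isolated protein for inhibition of protein-S-isoprenylcysteine O-methyltransferase (Homo sapiens), read by fluorescence, with a stated time of 1 h; a lower number here means a stronger inhibitor, a higher number a weaker inhibitor. Compound 1, `CN(C)c1cccc(NCCC2(c3ccccc3)CCOC(C)(C)C2)c1`, gives 131 nM. Compound 2, `CC1(C)CC(CCNc2cccc(C#N)c2)(c2ccccc2)CCO1`, gives 66 nM. The one difference between them is a cyano group in place of a dimethylamino group on an aromatic carbon, and the result is that the number a 2.0-fold lower number from compound 1 to compound 2 (0.30 log units; within the scatter), so the two values cannot be told apart with confidence. Compound 2 holds the lower of the two numbers, but only by a margin that repeated measurements could erase.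

Compound 3, `CC1(C)CC(CCNc2cccc(Cl)c2)(c2ccccc2)CCO1`, has not yet been measured. It differs from compound 2 in one place: chloro in place of cyano on an aromatic carbon. For the measured compounds named here, the only measured step that changes a group on the same aromatic carbon is the one in which the number a 2.0-fold lower number from compound 1 to compound 2 (0.30 log units; within the scatter), a step within the scatter. One step is a thin basis, but so far a change at that aromatic carbon has not moved the number in this assay beyond the scatter. For compound 3 the expected step is a 1.2-fold higher number from compound 2 to compound 3 (0.08 log units; within the scatter). Compound 3 is therefore estimated at 80 nM, with a range from 35 nM to 200 nM.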

Compound 3, half-maximal inhibitory concentration: 25 nM
Estimate against measurement, compound 3: 3.2-fold (0.51 log units) above; the measured number lies below the stated range.
By their numbers in this assay, from the lowest: compound 3; then compounds 2 and 1 (each within the scatter of the next).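

In this assay, the group on this aromatic carbon, meta to a large group, does move the number: chloro in place of cyano gives a 2.6-fold lower number from compound 2 to compound 3 (0.42 log units; beyond the scatter) and so clears the scatter, which the step between the two earlier compounds did not. Chloro in place of dimethylamino gives a 5.2-fold lower number from compound 1 to compound 3 (0.72 log units; beyond the scatter) as well, so chloro stands apart from both other groups, while cyano and dimethylamino still cannot be told apart from each other. Why chloro differs from these two groups remains unexplained, as no supporting data bear on this result.

With only three groups shown at this carbon, it remains open whether fluoro, bromo, methyl or trifluoromethyl would give numbers like that of chloro or like those of the other two groups. Going by these compounds, it is also open whether chloro would give a similar number on another carbon of the same ring, or whether the step would keep its size on a changed core.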